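The compounds below may be only part of what the source reports. "The series", "measured", "known", "first", "only" and "open" are said of these compounds alone.

Compound 1 `N#CC1=C(N)Oc2c(c3nc4ccccc4nc3c3ccccc23)C12C(=O)N(Cc1cnnn1-c1ccccc1Br)c1ccccc12` is a compound whose effect on the growth of normal liver cells was tested in an ADME assay on L02 cells (Homo sapiens) for antiproliferative activity, read by MTT assay, with a stated time of 48 h; a lower number here means a stronger inhibitor, a higher number a weaker inhibitor. In this assay compound 1 gives > 50000 nM, which is a limit of the assay rather than a measured number. Compound 2 `N#CC1=C(N)Oc2c(c3nc4ccccc4nc3c3ccccc23)C12C(=O)N(Cc1cnnn1-c1cccc(S(N)(=O)=O)c1)c1ccccc12` differs from compound 1 only in carrying a 3-sulfamoylphenyl in place of a 2-bromophenyl on an aromatic nitrogen. In this assay compound 2 likewise gives > 50000 nM, again a limit and not a number. The step that the two limits leave unreadable from compound 1 to compound 2 therefore cannot be read, since (the limit of > 50000 nM in this assay, at which 2 of the 2 values shown sit).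

Compound 3 `Cc1ccc(-n2nncc2CN2C(=O)C3(C(C#N)=C(N)Oc4c3c3nc5ccccc5nc3c3ccccc43)c3ccccc32)c(C)c1` is the compound not yet measured. It differs from compound 1 by 2,4-dimethylphenyl in place of 2-bromophenyl on an aromatic nitrogen. For the measured compounds named here, the only measured step that touches the same aromatic nitrogen is the one to compound 2, and it gives no readable size, so there is no basis for expecting a step beyond the scatter in either direction. Compound 3 is therefore expected to stay near the limit, with an estimated value of 80000 nM between 30000 nM and 300000 nM, an expected step that the limit leaves unreadable from compound 1 to compound 3.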

Compound 3, half-maximal inhibitory concentration: > 50000 nM
Compound 3 ended at the assay's limit; the forecaster's own chance of this, stated with the estimate: 80%; the middle value lies beyond the limit too.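

In this assay compound 3 gives > 50000 nM, which is a limit and not a number. For the compounds shown here, no step among compound 1, compound 2 and compound 3 can therefore be read: the limit of > 50000 nM in this assay, at which 3 of the 3 values shown sit. The compounds shown leave open how far each lies past that limit, and whether any group on this aromatic nitrogen would give a measurable value.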